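The compounds below may be only part of what the source reports. "The series", "measured", "known", "first", "only" and "open" are said of these compounds alone.

Of the compounds shown here, three sharing one core have been tested in a functional assay on MDA-MB-231 cells (Homo sapiens) for antiproliferative activity, read by sulforhodamine B assay, with a stated time of 48 h; on this read-out higher numbers stand for weaker inhibition and lower numbers for stronger inhibition. Compound 1 `NS(=O)(=O)c1ccc(N/C(S)=N\c2ccnc3cc(C(F)(F)F)ccc23)cc1`, which carries a hydrogen on the sulfonamide nitrogen, gives 52900 nM in this assay. Compound 2 `O=S(=O)(Nc1nccs1)c1ccc(N/C(S)=N\c2ccnc3cc(C(F)(F)F)ccc23)cc1` gives 24400 nM, and compound 3 `O=S(=O)(Nc1ccccn1)c1ccc(N/C(S)=N\c2ccnc3cc(C(F)(F)F)ccc23)cc1` gives 49300 nM. Compound 3 stands second highest of the three numbers, within the scatter of compound 1 and beyond it only against compound 2. The steps behind these numbers are a 2.2-fold lower number from compound 1 to compound 2 (0.34 log units; beyond the scatter), a 1.1-fold lower number from compound 1 to compound 3 (0.03 log units; within the scatter) and a 2.0-fold higher number from compound 2 to compound 3 (0.31 log units; beyond the scatter).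

Compound 4 `COc1ncnc(NS(=O)(=O)c2ccc(N/C(S)=N\c3ccnc4cc(C(F)(F)F)ccc34)cc2)c1OC` has not yet been measured. It differs from compound 3 in one place: 5,6-dimethoxypyrimidin-4-yl in place of pyridin-2-yl on a sulfonamide nitrogen. The step that bears most directly on this change is the earlier exchange of one ring for another on the same nitrogen, a 2.0-fold higher number from compound 2 to compound 3 (0.31 log units; beyond the scatter), a modest step; the other two steps were of similar or smaller size. A step of comparable size is therefore expected, leaning toward a lower number: a 1.4-fold lower number from compound 3 to compound 4 (0.15 log units; within the scatter). For compound 4 the estimate in this assay is 35000 nM, with a range from 15000 nM to 80000 nM.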

Compound 4, half-maximal inhibitory concentration: 83000 nM
Estimate against measurement, compound 4: 2.4-fold (0.38 log units) below; measured number outside the range, above it.
By their numbers in this assay, from the lowest: compound 2; then compounds 3, 1 and 4 (each within the scatter of the next).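

In this assay, putting the larger 5,6-dimethoxypyrimidin-4-yl ring on the sulfonamide nitrogen gives a 1.7-fold higher number from compound 3 to compound 4 (0.23 log units; within the scatter) and a 1.6-fold higher number from compound 1 to compound 4 (0.20 log units; within the scatter), so this ring cannot be told apart from either the pyridin-2-yl ring or plain hydrogen. Among these compounds, only the comparison with the 1,3-thiazol-2-yl ring clears the scatter, at a 3.4-fold higher number from compound 2 to compound 4 (0.53 log units; beyond the scatter), which leaves compound 2 as the one compound set apart on this nitrogen, and only modestly. Nothing available explains why that ring stands apart.

Going by these compounds, it remains open whether another five-membered ring, such as oxazol-2-yl, would match the number of compound 2. On these data alone, it is also open how a group without a ring, such as acetyl or methyl, would behave on this nitrogen.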